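A few compounds are considered here, and "the series" means these few. Any claim that something is new, unique, unknown or untested is made for them only; others in the source may bear on it.

In an ADME assay on a cell-free system (plasma, Homo sapiens) for metabolic stability, read by LC-MS (a lower number here means that the compound disappears faster, a higher number that the compound lasts longer), compound 1 `COc1ccc2c(c1)c(CC(=O)OCCOc1ccc3oc(=O)ccc3c1)c(C)n2C(=O)c1ccc(Cl)cc1` gives > 4 h, and this is a limit of the assay rather than a number. Within the data shown here, compound 2 `CC(C(=O)OCCOc1ccc2oc(=O)ccc2c1)c1cccc(C(=O)c2ccccc2)c1` gives 0.517 h, the only actual number so far in this assay. Compound 3 `CC(C(=O)OCCOc1ccc2ccc(=O)oc2c1)c1cccc(C(=O)c2ccccc2)c1` differs from compound 2 in one place, on an oxygen on a saturated carbon, where the same atoms are joined differently: a group of 11 heavy atoms (9 carbon, 2 oxygen; one six-membered aromatic ring of carbon only, one six-membered aromatic ring with 1 hetero atom) in place of a group of 11 heavy atoms (9 carbon, 2 oxygen; one six-membered aromatic ring of carbon only, one six-membered aromatic ring with 1 hetero atom), on an oxygen on a saturated carbon. Among the measured compounds shown here, no measured pair here shows what a change of this kind does, so the expectation rests on compound 2 and its 0.517 h. No shift in either direction beyond the usual scatter is expected, and the expected step is a 1.0-fold lower number from compound 2 to compound 3 (0.01 log units; within the scatter). The estimated half-life of compound 3 is 0.5 h, with an expected range of 0.2 h to 1.2 h.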

Compound 3, half-life: 0.2 h
The estimate for compound 3 lay 2.5-fold (0.40 log units) above the measured number; low and high end bracket the measured number.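

The step shows that this position responds to how the atoms are joined, not only to which atoms are present: with the same atoms rearranged in the group on an oxygen on a saturated carbon, this assay gives a 2.6-fold lower number from compound 2 to compound 3 (0.41 log units; beyond the scatter). Among these compounds, the earlier compounds offered no pair differing in one place, so this is the only reading of a change here, and it is a modest one. The two groups match in every count computed for them, so those counts do not separate them, and nothing at hand bears on what lies behind the step.

Going by these compounds, compound 1 gives > 4 h, which is a limit of the assay, so what the same change does in the core of compound 1 stays open. Also open, on these data alone, is whether an amine or a carboxylic acid on this group, or a longer chain at the saturated chain carbon, would move the half-life.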